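Azido for amino on the side chain of compound 2

The source may hold more compounds than are shown below. What is called first, only, known or untested is meant among the compounds shown, and "the series" means these compounds.

Going by the values given here, compound 2, with the structure `Cc1cn([C@H]2C[C@H](CN)[C@@H](COP(=O)(O)O)O2)c(=O)[nH]c1=O`, is the more potent of the two compounds measured so far in an assay on isolated protein for inhibition of thymidine kinase, cytosolic (Homo sapiens); a higher number here means a weaker inhibitor, a lower number a stronger inhibitor: compound 2 gives 4700 nM. Among the compounds with values here, its only neighbour, compound 1 with the structure `Cc1cn([C@H]2C[C@H](CF)[C@@H](COP(=O)(O)O)O2)c(=O)[nH]c1=O`, gives 40000 nM in this assay, and the step of an 8.5-fold lower number from compound 1 to compound 2 (0.93 log units; beyond the scatter) is the single comparison available.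

Compound 3, with the structure `Cc1cn([C@H]2C[C@H](CN=[N+]=[N-])[C@@H](COP(=O)(O)O)O2)c(=O)[nH]c1=O`, differs from compound 2 by the change (azido in place of amino on a saturated chain carbon bound to a saturated ring carbon); read one bond further out, the aminomethyl of compound 2 becomes the azidomethyl of compound 3. Within the data shown here, no measured step involves an azido group, so the only bearing on it is indirect: the step from compound 1 to compound 2 shows that swapping the group on this chain carbon can move the number by a modest amount, and the azido group shares with the fluoro group of compound 1 the lack of a hydrogen-bond donor that the amino group carries. On that basis compound 3 is expected to fall back toward compound 1, with a step of a 4.3-fold higher number from compound 2 to compound 3 (0.63 log units; beyond the scatter). The estimate for compound 3 in this assay is 20000 nM, within a range of 5000 nM to 80000 nM.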

Compound 3, inhibition constant: 32000 nM
Beside the measured number, compound 3's estimate is 1.6-fold (0.20 log units) below it; measured number inside the range.
By their numbers in this assay, from the lowest: compound 2; then compounds 3 and 1 (each within the scatter of the next).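

In this assay, the change to azido undoes the gain seen with amino on this chain carbon: with a 6.8-fold higher number from compound 2 to compound 3 (0.83 log units; beyond the scatter) in hand, the lower number of compound 2 is shown not to extend to a second replacement of the amino group. The step of a 1.3-fold lower number from compound 1 to compound 3 (0.10 log units; within the scatter) leaves azido and fluoro indistinguishable in this assay, even though the two groups are different in kind, so among the three groups shown it is amino alone that stands apart, rather than the three spreading along a graded series. No accompanying measurement speaks to what sets the amino group apart, and the difference between amino and azido in heavy atoms and in hydrogen-bond donors stays an observation without an explanation.

The compounds shown leave open whether the lower number belongs to the amino group alone or would also appear with a hydroxyl, a methylamino or an acetamido group on this chain carbon. They also leave open whether an amine carried on a longer chain, such as aminoethyl in place of aminomethyl, would hold, improve or lose that number.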